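Moving the fluorine from 2-fluorophenyl to 3-fluorophenyl

The source may report more compounds than this note shows. Statements on the series, on what has been measured and on what is new or still open speak of the compounds shown alone.

Compound 1 `c1ccc(Cn2ccc3nc(-c4ccccc4)nc-3c2)cc1` and compound 2 `Fc1ccccc1Cn1ccc2nc(-c3ccccc3)nc-2c1` share one core and differ by a single fluoro group. In an ADME assay on MDBK cells (Bos taurus) for cytotoxicity (on this read-out higher numbers stand for lower toxicity in this test and lower numbers for higher toxicity in this test), compound 1 gives > 100000 nM as a limit of the assay and not a number. In this assay compound 2 gives > 100000 nM as a limit too, not a number. Compound 2 therefore stands at the limit of > 100000 nM in this assay, at which 2 of the 2 values shown sit, with no exact figure to start from.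

Compound 3 `Fc1cccc(Cn2ccc3nc(-c4ccccc4)nc-3c2)c1` has the same atoms as compound 2, joined differently, and the change (3-fluorophenyl in place of 2-fluorophenyl on a saturated chain carbon bound to an aromatic nitrogen) is 3-fluorophenyl in place of 2-fluorophenyl on a saturated chain carbon bound to an aromatic nitrogen. Among the compounds with values here, the one measured step that bears on this is a step that the two limits leave unreadable from compound 1 to compound 2 with fluoro in place of hydrogen on an aromatic carbon, so it gives no size to carry over. In this assay no step beyond the usual scatter is therefore expected, in either direction. The estimated step of a number no higher from compound 2 to compound 3 (the limit leaves the size open) reflects this. The estimate for compound 3 is 100000 nM with an expected range from 50000 nM to 200000 nM and another limit is the likeliest report.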

Compound 3, half-maximal cytotoxic concentration: > 100000 nM
Compound 3 ended at the assay's limit; the forecaster's own chance of this, stated with the estimate: 85%; the middle value sits exactly at the limit.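

In this assay compound 3 gives a limit and not a number, as compound 1 and compound 2 do, so no step among these compounds can be read: the limit of > 100000 nM in this assay, at which 3 of the 3 values shown sit. With no exact figure for any of them, the compounds shown leave open whether adding the fluoro group, or using 3-fluorophenyl in place of 2-fluorophenyl, changes this read-out at all.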